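The compounds below may be only part of what the source reports. "The series", "measured", "known", "first", "only" and "open" are said of these compounds alone.

Measured in a functional assay on DU-145 cells (Homo sapiens) for antiproliferative activity, read by WST assay, with a stated time of 3 days; on this read-out higher numbers stand for weaker inhibition and lower numbers for stronger inhibition:
- compound 1 `CCOc1c(-c2cc(OC)c(OC)c(OC)c2)oc2ccccc2c1=O`: 6200 nM
- compound 2 `CCCN(CCC)CCCCCOc1c(-c2cc(OC)c(OC)c(OC)c2)oc2ccccc2c1=O`: 24200 nM

Compound 2 holds the higher of the two numbers, so it is the weaker inhibitor of the pair. Compound 3 `CCCCN(CCCC)CCCCOc1c(-c2cc(OC)c(OC)c(OC)c2)oc2ccccc2c1=O` is not yet measured. It differs from compound 2 as follows: dibutylamino in place of (dipropylamino)methyl on a saturated chain carbon, four bonds along the chain from an oxygen on an aromatic ring. Among the measured compounds shown here, the only measured step, a 3.9-fold higher number from compound 1 to compound 2 (0.59 log units; beyond the scatter), puts 3-(dipropylamino)propyl in place of hydrogen, a much larger change, so it bears only loosely here. No step beyond the scatter is expected in this assay. The expected step is a 1.1-fold lower number from compound 2 to compound 3 (0.04 log units; within the scatter). For compound 3 the estimate is 22000 nM, with an expected range of 10000 nM to 50000 nM.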

Compound 3, half-maximal inhibitory concentration: 15300 nM
For compound 3 the middle estimate is 1.4-fold (0.16 log units) above the measured one; low and high end bracket the measured number.
By their numbers in this assay, from the lowest: compound 1; then compounds 3 and 2 (each within the scatter of the next).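

In this assay dibutylamino in place of (dipropylamino)methyl gives a 1.6-fold lower number from compound 2 to compound 3 (0.20 log units; within the scatter) and so does not separate the two compounds at this place, four bonds along the chain from an oxygen on an aromatic ring. 2-(Dibutylamino)ethyl in place of hydrogen gives a 2.5-fold higher number from compound 1 to compound 3 (0.39 log units; beyond the scatter) and so, like compound 2, compound 3 stands on the weaker side of compound 1.

Open, from the compounds shown here alone, is whether a cyclic amine such as piperidine, a primary amine or a longer chain at this place would read differently. Going by these compounds, a carboxylic acid at the chain end is equally open. No evidence on the cause of either step is at hand.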